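This account rests on a few compounds, and the source may have more. Where it says the series, first, only, none or still open, it means among the compounds named here.

Compound 3 `O=C(/C=C/c1ccc(F)cc1)c1ccccc1` and compound 1 `O=C(/C=C/c1ccc(Cl)cc1)c1ccccc1` share one core and differ in a single place: compound 3 carries fluoro where compound 1 carries chloro. In a functional assay on CAL-51 cells (Homo sapiens) for inhibition, read by sulforhodamine B assay, with a stated time of 3 days (on this read-out higher numbers stand for weaker inhibition of growth and lower numbers for stronger inhibition of growth), compound 3 gives 2780 nM, while compound 1 gives 5850 nM. The change between them, (chloro in place of fluoro on an aromatic carbon), made a step of a 2.1-fold higher number from compound 3 to compound 1 (0.32 log units; beyond the scatter), so the chloro compound inhibited growth somewhat less strongly.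

Compound 2 `Cc1ccc(COc2ccc(C(=O)/C=C/c3ccc(F)cc3)cc2)cc1` has a larger core; how that core differs from the core of compound 3 is not broken down here. In this assay compound 2 reached only a limit of the measurement, > 50000 nM, so no number is known for it. This limit is the limit of > 50000 nM in this assay, at which 1 of the 3 values shown sits.

Compound 4 `Cc1ccc(COc2ccc(C(=O)/C=C/c3ccc(Cl)cc3)cc2)cc1` is not yet measured. It stands to compound 2 as compound 1 stands to compound 3, through the same change, (chloro in place of fluoro on an aromatic carbon). The step from compound 2 to compound 4 is expected to be about a step that the limit leaves unreadable from compound 2 to compound 4, resting on compound 1 having given a 2.1-fold higher number from compound 3 to compound 1 (0.32 log units; beyond the scatter) and on compound 2 already sitting at the limit of > 50000 nM in this assay, at which 1 of the 3 values shown sits. Compound 4 is therefore estimated at 90000 nM, most likely again reported only as a limit.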

Compound 4, concentration for 50% growth inhibition: > 50000 nM
Compound 4 was reported as a limit; the forecaster's own chance of this, stated with the estimate: 85%; the middle value does not contradict the limit.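

Compound 2 and compound 4 each reached only a limit in this assay, not a number, so no step between them can be read: the limit of > 50000 nM in this assay, at which 2 of the 4 values shown sit.

The compounds shown leave open whether 4-chlorophenyl in place of 4-fluorophenyl changes growth inhibition at all on the larger core shared by compound 2 and compound 4.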